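The source may hold more compounds than are shown below. What is called first, only, known or untested is meant among the compounds shown, and "the series" means these compounds.

Compound 1 `CCC1C(=O)N(C)c2cnc(Nc3ccc(S(=O)(=O)NC)cc3)nc2N1c1ccn(C)n1` gives 71.6 nM in an assay for inhibition of serine/threonine-protein kinase PLK2 (Homo sapiens), read by FRET and Z'-LYTE, with a stated time of 1 h; a higher number here means a weaker inhibitor, a lower number a stronger inhibitor. Compound 2 `CCCNS(=O)(=O)c1ccc(Nc2ncc3c(n2)N(c2ccn(C)n2)C(CC)C(=O)N3C)cc1` gives 190 nM in this assay. Compound 3 `CCC1C(=O)N(C)c2cnc(Nc3ccc(S(N)(=O)=O)cc3)nc2N1c1ccn(C)n1` gives 121 nM in this assay.

Among these three numbers compound 3 stands second highest, but its neighbours lie within the scatter of it: a 1.6-fold lower number from compound 2 to compound 3 (0.20 log units; within the scatter) and a 1.7-fold higher number from compound 1 to compound 3 (0.23 log units; within the scatter). Compound 4 `CCC1C(=O)N(C)c2cnc(Nc3ccc(S(=O)(=O)NCCCO)cc3)nc2N1c1ccn(C)n1` carries the change (3-hydroxypropyl in place of hydrogen on a sulfonamide nitrogen). The step that bears most on it is the lengthening of the substituent on the same nitrogen, a 2.7-fold higher number from compound 1 to compound 2 (0.42 log units; beyond the scatter), a modest rise, while the removal of propyl, a 1.6-fold lower number from compound 2 to compound 3 (0.20 log units; within the scatter), stayed within the scatter. A small rise in this assay, at most modest, is therefore expected. Compound 4 is estimated at 170 nM, with a range of 70 nM to 420 nM. For compound 4 this would mean an expected step of a 1.4-fold higher number from compound 3 to compound 4 (0.15 log units; within the scatter).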

Compound 4, half-maximal inhibitory concentration: 192 nM
Beside the measured number, compound 4's estimate is 1.1-fold (0.05 log units) below it; the measured number falls inside the stated range.
By their numbers in this assay, from the lowest: compounds 1, 3, 2 and 4 (each within the scatter of the next, the first and the last beyond it).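

With the 3-hydroxypropyl group on the sulfonamide nitrogen, the reading in this assay stays level with that of the unsubstituted sulfonamide (a 1.6-fold higher number from compound 3 to compound 4 (0.20 log units; within the scatter)), so this group on this nitrogen makes no difference that can be read. The terminal hydroxy adds nothing readable to the propyl chain either (a 1.0-fold higher number from compound 2 to compound 4 (0.00 log units; within the scatter)), yet the hydroxylated chain stands apart from the methyl group (a 2.7-fold higher number from compound 1 to compound 4 (0.43 log units; beyond the scatter)). Nothing shown explains these numbers.

On these data alone, whether an amine or a carboxylic acid at the end of the chain would read differently stays open. So does the effect of a longer chain on this nitrogen.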